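Changing the aryl group on the shared core

The source may report more compounds than this note shows. Statements on the series, on what has been measured and on what is new or still open speak of the compounds shown alone.

Measured so far:
compound 1 `Cc1ccc(-c2cc3ncn([C@H]4CCN(C(=O)N(C)[C@H]5CCN(C)C5)C4)c(=O)c3s2)cc1` gives 15 nM in an assay on isolated protein for binding affinity to melanin-concentrating hormone receptor 1 (Homo sapiens); on this read-out higher numbers stand for weaker inhibition and lower numbers for stronger inhibition;
compound 2 `Cc1ccc(-c2cc3ncn([C@H]4CCN(C(=O)N(C)[C@H]5CCN(C)C5)C4)c(=O)c3s2)c(C)c1` gives 49 nM in this assay.

Compound 2 has the highest of the two numbers; its nearest neighbour is compound 1, and the step of a 3.3-fold higher number from compound 1 to compound 2 (0.51 log units; beyond the scatter) is beyond the scatter. Compound 3 `CN1CC[C@H](N(C)C(=O)N2CC[C@H](n3cnc4cc(-c5ccc(OC(F)(F)F)cc5)sc4c3=O)C2)C1` has not yet been measured. It differs from compound 2 in one place: 4-(trifluoromethoxy)phenyl in place of 2,4-dimethylphenyl on an aromatic carbon. Within the data shown here, the only measured step that bears on this is a 3.3-fold higher number from compound 1 to compound 2 (0.51 log units; beyond the scatter), a modest change in one substituent of this ring. Among the measured compounds shown here, the trifluoromethoxy group itself has no measured counterpart, so the expectation rests mainly on that one step. Compound 3 is expected to show a 2.5-fold lower number from compound 2 to compound 3 (0.39 log units; beyond the scatter), a lower number in this assay, estimated at 20 nM within a range of 6 nM to 65 nM.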

Compound 3, inhibition constant: 39 nM
For compound 3 the middle estimate is 2.0-fold (0.29 log units) below the measured one, within the range that was stated.
By their numbers in this assay, from the lowest: compound 1; then compounds 3 and 2 (each within the scatter of the next).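

In this assay, 4-(trifluoromethoxy)phenyl in place of 2,4-dimethylphenyl gives a 1.3-fold lower number from compound 2 to compound 3 (0.10 log units; within the scatter), so these two quite different groups cannot be told apart at this position. Trifluoromethoxy in place of methyl gives a 2.6-fold higher number from compound 1 to compound 3 (0.41 log units; beyond the scatter), so compound 1 keeps the lowest number of the three, and the one methyl-bearing aryl group stays ahead of both alternatives. Nothing measured here explains these numbers. As far as these compounds go, it remains open how an unsubstituted phenyl ring would compare, and whether chlorine, an amine or a carboxylic acid in place of that methyl would match compound 1.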